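From methoxy to butoxy on a shared core

The source may hold more compounds than are shown below. What is called first, only, known or untested is meant among the compounds shown, and "the series" means these compounds.

Measured so far in a functional assay on A2780 cells (Homo sapiens) for antiproliferative activity, read by MTT assay, with a stated time of 3 days; a lower number here means a stronger inhibitor, a higher number a weaker inhibitor:
Compound 1, `COC1(c2ccc(Br)cc2)SC=C(C)n2c1noc2=O`, gives 148000 nM.
Compound 2, `COC1(c2ccc(Cl)cc2)SC=C(C)n2c1noc2=O`, gives 166000 nM.
Compound 3, `CC1=CSC(O)(c2ccc([N+](=O)[O-])cc2)c2noc(=O)n21`, gives > 100000 nM, which is a limit of the assay and not a number.

Going by the values given here, of the two numbers reported, compound 2 carries the nominally higher one, but its only neighbour is compound 1, and the step of a 1.1-fold higher number from compound 1 to compound 2 (0.05 log units; within the scatter), chloro in place of bromo on an aromatic carbon, lies within the scatter, so the two cannot be told apart. Compound 3 is known only through (the limit of > 100000 nM in this assay, at which 1 of the 3 values shown sits), so it gives no number to compare against.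

Compound 4, `CCCCOC1(c2ccc(Cl)cc2)SC=C(C)n2c1noc2=O`, is compound 2 with a longer group on the oxygen: propyl in place of hydrogen on a saturated chain carbon bound to an oxygen on a saturated carbon. Among the compounds with values here, no measured step touches this part of the molecule; the one step that has been measured swaps halogens and was within the scatter, so it offers no guidance on lengthening the chain bound to the oxygen. With nothing to point either way, the step of a 1.1-fold lower number from compound 2 to compound 4 (0.04 log units; within the scatter) is expected to stay within the scatter. Compound 4 is therefore estimated at 150000 nM, with a range from 50000 nM to 450000 nM.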

Compound 4, half-maximal inhibitory concentration: 89000 nM
For compound 4 the middle estimate is 1.7-fold (0.23 log units) above the measured one, within the range that was stated.
By their numbers in this assay, from the lowest: compounds 4, 1 and 2 (each within the scatter of the next).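

In this assay, going by these compounds alone, the swap of methoxy for butoxy gives the first measured step at the chain on the oxygen, and the step is a 1.9-fold lower number from compound 2 to compound 4 (0.27 log units; within the scatter). This shows that compound 2 and compound 4 cannot be told apart, even though the change from methyl to butyl adds more atoms than the earlier exchange of halogens on the aromatic carbon, where the step was a 1.1-fold higher number from compound 1 to compound 2 (0.05 log units; within the scatter). At this level of resolution, neither change has produced a difference that can be read, and no information given here bears on why this step is so small.

On these data alone, whether a different group on this oxygen would move the number beyond the scatter stays open, for example a chain ending in an amine or a carboxylic acid, or a much longer chain such as decyl. Compound 3 stands only as a limit and not a number, so it cannot be read against the other compounds: the limit of > 100000 nM in this assay, at which 1 of the 4 values shown sits.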